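Chloro to iodo in a series near the assay limit

The source may report more compounds than this note shows. Statements on the series, on what has been measured and on what is new or still open speak of the compounds shown alone.

In an ADME assay on RAW264.7 cells (Mus musculus) for cytotoxicity, read by MTT assay, with a stated time of 24 h (on this read-out lower numbers stand for higher toxicity in this test and higher numbers for lower toxicity in this test), compound 1 `O=C(Nc1ccc(Cl)cc1F)c1ccccc1OCc1ccc(F)cc1F` gives > 40000 nM, which is a limit and not a number. Compound 2 `COc1ccc(C(=O)Nc2ccc(Cl)cc2F)c(O)c1` gives 32300 nM. Compound 3 `COc1ccc(C(=O)Nc2ccc(Cl)cc2F)c(OCc2ccc(F)cc2F)c1` gives > 40000 nM, again a limit and not a number. Two steps lead to it: a step that the two limits leave unreadable from compound 1 to compound 3 on adding methoxy, and an at least 1.2-fold higher number from compound 2 to compound 3 (0.09 log units; that floor lies within the scatter) on adding 2,4-difluorobenzyl. Compound 4 `COc1ccc(C(=O)Nc2ccc(I)cc2F)c(OCc2ccc(F)cc2F)c1` carries iodo in place of chloro on an aromatic carbon. Neither measured step changes that halogen, so they offer no size for this swap. What is expected in this assay is a number no higher from compound 3 to compound 4 (the limit leaves the size open), with no shift beyond the scatter and quite possibly only a limit again. Compound 4 is estimated at 40000 nM, with an expected range from 18000 nM to 90000 nM.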

Compound 4, half-maximal cytotoxic concentration: 36800 nM
Compound 4: middle estimate off by 1.1-fold (0.04 log units), on the high side, and the stated range covers the measured number.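

In this assay, among the compounds shown here, iodo in place of chloro, para to a large group, gives an at least 1.0-fold lower number from compound 3 to compound 4 (0.03 log units; that floor lies within the scatter), a reading for this halogen that no earlier step offered. Compound 3 gives > 40000 nM, which is a limit and not a number, so the true size of the swap stays hidden. The iodo compound still reads close to the top of what the test can report: the limit of > 40000 nM in this assay, at which 2 of the 4 values shown sit.

Going by these compounds, how a bromo group or an amine at this place would read stays open. So does whether the same swap would read alike on compound 2, with its free hydroxyl.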